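Series notes: aromatic amine replacement at the para position

A few compounds are considered here, and "the series" means these few. Any claim that something is new, unique, unknown or untested is made for them only; others in the source may bear on it.

In a physicochemical assay for lipophilicity (a higher number here means a more lipophilic compound, a lower number a more polar compound), compound 1 `NS(=O)(=O)Oc1ccc2c(c1)CN(C(=O)c1ccc(N3CCCCC3)cc1)CC2` gives 1.93. Compound 2 `CN(C)CCCN(Cc1ccccc1)c1ccc(C(=O)N2CCc3ccc(OS(N)(=O)=O)cc3C2)cc1` gives 1.93 and compound 3 `NS(=O)(=O)Oc1ccc2c(c1)CN(C(=O)c1ccc(N(CCCO)Cc3ccccc3)cc1)CC2` gives 1.93, so compound 1 stands level with both at the digits printed, within the scatter of this assay. Within the data shown here, the one measured step, from compound 2 to compound 3, is no change at the digits printed from compound 2 to compound 3 (within the scatter); it swaps a dimethylamino for a hydroxy on the chain and says nothing directly about the aromatic amine that changes here.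

Compound 4 `CCN(Cc1ccncc1)c1ccc(C(=O)N2CCc3ccc(OS(N)(=O)=O)cc3C2)cc1` differs from compound 1 as follows: ethyl((pyridin-4-yl)methyl)amino in place of piperidin-1-yl on an aromatic carbon. Among the measured compounds shown here, no measured pair in the set exchanges a saturated ring amine for an open-chain amine carrying a pyridine, so the expectation rests only on the flat run of values across compounds 1, 2 and 3. Compound 4 is therefore expected to stay close to compound 1, with a step of a number 0.13 log units lower from compound 1 to compound 4 (within the scatter) that may not exceed the scatter. The estimate for compound 4 in this assay is 1.8, within a range of 1.3 to 2.4.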

Compound 4, partition coefficient: 1.93
Compound 4: middle estimate off by 0.13 log units, on the low side; measured number inside the range.
By their numbers in this assay, from the lowest: compounds 1, 2, 3 and 4 (each within the scatter of the next).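

In this assay, among these compounds, the exchange of piperidin-1-yl for ethyl((pyridin-4-yl)methyl)amino on an aromatic carbon reads as no change at the digits printed from compound 1 to compound 4 (within the scatter) and gives the series its one measured step at this position, where the earlier step touched only the end of a chain. The step is a large change in structure: a six-membered non-aromatic ring leaves, a six-membered aromatic ring with 1 hetero atom enters, and the group goes from 6 heavy atoms to 10 heavy atoms and from 1 hydrogen-bond acceptor to 2, yet the read-out does not separate the two compounds. No measurement in hand accounts for this result.

From the compounds shown here alone, the pyridine ring and the open-chain amine enter in one step, so their separate contributions remain open. Also open, going by these compounds, is whether a carboxylic acid in place of piperidin-1-yl on the same aromatic carbon would stay level with compound 1.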